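The source may report more compounds than this note shows. Statements on the series, on what has been measured and on what is new or still open speak of the compounds shown alone.

Measured so far in an assay on isolated protein for inhibition of ubiquitin carboxyl-terminal hydrolase 7 (Homo sapiens), read by TR-FRET, with stated times of 75 min and 1 h; on this read-out higher numbers stand for weaker inhibition and lower numbers for stronger inhibition:
- compound 1 `O=C(CCc1ccccc1)N1CCC(O)(CN2C=Nc3cc(NCCN4CCCCC4)ccc3C2O)CC1` gives 37000 nM
- compound 2 `O=C(CCc1ccccc1)N1CCC(O)(CN2C=Nc3cc(NCCN4CCCC4)ccc3C2O)CC1` gives 4860 nM
- compound 3 `CN(C)CCNc1ccc2c(c1)N=CN(CC1(O)CCN(C(=O)CCc3ccccc3)CC1)C2O` gives 5980 nM

Compound 3 stands second highest of the three numbers. Its nearest neighbour is compound 2, and the gap a 1.2-fold higher number from compound 2 to compound 3 (0.09 log units; within the scatter) lies within the scatter, so the two cannot be told apart. Compound 1 is the furthest away, with a 6.2-fold lower number from compound 1 to compound 3 (0.79 log units; beyond the scatter) and a 7.6-fold lower number from compound 1 to compound 2 (0.88 log units; beyond the scatter) separating it from the other two.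

Compound 4 `CC(CC(=O)N1CCC(O)(CN2C=Nc3cc(NCCN(C)C)ccc3C2O)CC1)c1ccccc1` differs from compound 3 by methyl in place of hydrogen on a saturated chain carbon bound to an aromatic carbon and a saturated chain carbon. None of the three measured steps touches this part of the molecule: all of them swap the amine at the end of the chain that hangs from the aromatic ring, and leave the phenethyl end unchanged. Within the data shown here, there is therefore no measured step that directly tests a methyl at this position, and the expectation rests on the absence of evidence for any effect rather than on a trend. The step of a 1.1-fold higher number from compound 3 to compound 4 (0.04 log units; within the scatter) in this assay is expected to stay within the scatter. Compound 4 is accordingly estimated at 6500 nM, with a range from 2000 nM to 20000 nM.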

Compound 4, half-maximal inhibitory concentration: 1540 nM
Estimate against measurement, compound 4: 4.2-fold (0.63 log units) above; measured number outside the range, below it.
By their numbers in this assay, from the lowest: compound 4; then compounds 2 and 3 (each within the scatter of the next); then compound 1.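

The earlier compounds shown here changed only the amine at the end of the chain on the aromatic ring, so they said nothing about the phenethylcarbonyl end of the molecule. In this assay, going from phenethylcarbonyl to (2-phenylpropyl)carbonyl gives a 3.9-fold lower number from compound 3 to compound 4 (0.59 log units; beyond the scatter) and shows that one added carbon on this saturated chain carbon, bound to an aromatic carbon and a saturated chain carbon, is enough to move the number beyond the scatter, towards stronger inhibition. No measurement available here explains this shift.

Still open, from the compounds shown here alone, is whether a larger group such as ethyl, or a hydroxyl group, on the same carbon would strengthen inhibition further or lose the gain. Also open, going by these compounds, is whether this methyl would give a similar step alongside the pyrrolidin-1-yl amine of compound 2 or the piperidin-1-yl amine of compound 1.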